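The compounds below may be only part of what the source reports. "The series", "measured", "known", "first", "only" and "open" are said of these compounds alone.

Of the compounds shown here, three of a shared core have been tested in a functional assay on CAKI-1 cells (Homo sapiens) for cytotoxicity, read by sulforhodamine B assay, with a stated time of 48 h, tested at 1 uM; a lower number here means a stronger effect, a higher number a weaker effect of the compound at the concentration tested. Compound 1 `COc1ccc(-c2cc(/C=C/C(=O)c3ccc(OC)c(OC)c3)[nH]n2)cc1` gives 77%, compound 2 `COc1cc(-c2cc(/C=C/C(=O)c3ccc(Cl)c(Cl)c3)[nH]n2)cc(OC)c1OC` gives 87%, and compound 3 `COc1ccc(C(=O)/C=C/c2cc(-c3cc(OC)c(OC)c(OC)c3)n[nH]2)cc1` gives 89%. On these numbers compound 3 stands highest of the three; compound 2 sits nearest, a number only slightly lower and within the scatter, while compound 1 sits furthest, a number lower by a gap beyond the scatter. Going by the values given here, the one step measured between neighbours, 4-methoxyphenyl in place of 3,4-dichlorophenyl on the carbonyl carbon, gave a number 2 percentage points higher from compound 2 to compound 3 (within the scatter).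

Compound 4 `COc1ccc(C(=O)/C=C/c2cc(-c3cc(OC)c(OC)c(OC)c3)n[nH]2)cc1OC` is the next step from compound 3: methoxy in place of hydrogen on an aromatic carbon. It sits on the six-membered aromatic ring of carbon only, ortho to a methoxy group and meta to a large group, so that the 4-methoxyphenyl becomes a 3,4-dimethoxyphenyl. Among the compounds with values here, no measured step touches this change; the one step known, from compound 2 to compound 3, alters a different part of the ring and was within the scatter. Compound 1 also carries a 3,4-dimethoxyphenyl on its carbonyl, yet it differs from compound 4 in a second place, so its value only hints at a somewhat lower number. Compound 4 is therefore expected to show a number 6 percentage points lower from compound 3 to compound 4 (within the scatter), which amounts to an estimated 83% in this assay, between 68% and 95%.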

Compound 4, a percentage reported as activity, at one concentration (the size of the read-out at that concentration, not a potency): 94%
The estimate for compound 4 lay 11 percentage points below the measured number; the range from low to high includes it.
By their numbers in this assay, from the lowest: compounds 1, 2, 3 and 4 (each within the scatter of the next, the first and the last beyond it).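

Placing a methoxy group on the aromatic carbon ortho to a methoxy group and meta to a large group, which turns the 4-methoxyphenyl into a 3,4-dimethoxyphenyl, gives (a number 5 percentage points higher from compound 3 to compound 4 (within the scatter)) in this assay, the first measured step at this position, and in this assay the added group cannot be told apart from the usual spread of repeated readings. The same holds when the dichlorinated group is compared directly. Here 3,4-dimethoxyphenyl in place of 3,4-dichlorophenyl on the carbonyl carbon gives (a number 7 percentage points higher from compound 2 to compound 4 (within the scatter)), so all three groups carried on that carbonyl by compounds 2, 3 and 4 lie within the scatter of one another at this single concentration. No separate measurement is available that could explain these numbers.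

Going by these compounds, whether a different group at the same aromatic carbon, such as an amine, a carboxylic acid or a longer alkoxy chain, would move the number beyond the scatter remains open. Also open, on these data alone, is how these compounds would compare across a range of concentrations, since a reading at one concentration gives the size of the effect there and not a potency.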